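A few compounds are considered here, and "the series" means these few. Any claim that something is new, unique, unknown or untested is made for them only; others in the source may bear on it.

Working notes on the amide series. Of the compounds shown here, three sharing one core have been measured in a functional assay on NCI-H1975 cells (Homo sapiens) for antiproliferative activity, read by MTT assay, with a stated time of 72 h; on this read-out lower numbers stand for stronger inhibition and higher numbers for weaker inhibition. Compound 1 `COc1cc(F)c(NC(=O)c2ccnc(O)c2)cc1Nc1nccc(-c2cn(C)c3ccccc23)n1` gives 5920 nM in this assay. Compound 2 `COc1ccc(C(=O)Nc2cc(Nc3nccc(-c4cn(C)c5ccccc45)n3)c(OC)cc2F)nc1` gives 16800 nM, and compound 3 `COc1cc(F)c(NC(=O)c2ccccn2)cc1Nc1nccc(-c2cn(C)c3ccccc23)n1` gives 16500 nM. Compound 3 therefore stands second highest of the three numbers: against compound 2 the two values sit within the scatter, with a 1.0-fold lower number from compound 2 to compound 3 (0.01 log units; within the scatter), while against compound 1 the gap is beyond it, a 2.8-fold higher number from compound 1 to compound 3 (0.45 log units; beyond the scatter).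

Compound 4 `COc1cc(F)c(NC(=O)c2ncccn2)cc1Nc1nccc(-c2cn(C)c3ccccc23)n1` is not yet measured. Its difference from compound 3 is pyrimidin-2-yl in place of pyridin-2-yl on a carbonyl carbon. Going by the values given here, no measured step exchanges one aromatic ring for another of this kind at the carbonyl carbon; the nearest precedents are the ring exchanges from compound 1, where a 2.8-fold higher number from compound 1 to compound 2 (0.45 log units; beyond the scatter) and a 2.8-fold higher number from compound 1 to compound 3 (0.45 log units; beyond the scatter) were both modest, and the substituent change on the same ring, where a 1.0-fold lower number from compound 2 to compound 3 (0.01 log units; within the scatter) stayed within the scatter. On that basis the step of a 1.0-fold lower number from compound 3 to compound 4 (0.01 log units; within the scatter) is expected to be small, most likely not beyond the scatter, with no clear direction. Compound 4 is accordingly estimated at 16000 nM in this assay, within a range of 6000 nM to 45000 nM.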

Compound 4, half-maximal inhibitory concentration: 13500 nM
Compound 4: the middle estimate sits 1.2-fold (0.07 log units) above what was measured; the measured number falls inside the stated range.
By their numbers in this assay, from the lowest: compound 1; then compounds 4, 3 and 2 (each within the scatter of the next).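

In this assay, pyrimidin-2-yl on the carbonyl carbon gives a 1.2-fold lower number from compound 3 to compound 4 (0.09 log units; within the scatter) and so reads the same as pyridin-2-yl, which shows that a ring with 2 hetero atoms in place of 1 does not separate from its parent at this position. The comparison with the methoxy-bearing ring gives the same picture, with a 1.2-fold lower number from compound 2 to compound 4 (0.09 log units; within the scatter) within the scatter, so pyrimidin-2-yl, pyridin-2-yl and 5-methoxypyridin-2-yl cannot be told apart on this read-out. Only the 2-hydroxypyridin-4-yl group remains separate from the others, and a 2.3-fold higher number from compound 1 to compound 4 (0.36 log units; beyond the scatter) extends that modest gap to a third ring, though the gap stays no larger than those already seen.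

Nothing at hand bears on the reason for this flat stretch of values. On these data alone, it remains open whether the separate standing of 2-hydroxypyridin-4-yl rests on the hydroxyl itself or on the ring's attachment, which a plain pyridin-4-yl group would address, and whether an amine or a carboxylic acid on the ring would move the number further.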